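Chloro in Place of Methoxy: What to Expect for Compound 4

The source may hold more compounds than are shown below. What is called first, only, known or untested is meant among the compounds shown, and "the series" means these compounds.

Of the compounds shown here, three have been tested in a functional assay on SMMC-7721 cells (Homo sapiens) for cytotoxicity, read by MTT assay, with a stated time of 4 days; a lower number here means a stronger inhibitor, a higher number a weaker inhibitor.
Compound 1 `C=C1C[C@]23C[C@@]1(O)CC[C@@H]2c1cccc(C)c1[C@@H]3Cn1cc(-c2ccc(C)cc2)nn1` gives > 20000 nM, a limit of the assay rather than a number.
Compound 2 `COc1ccc(-c2cn(C[C@H]3c4c(ccc(O)c4C)[C@@H]4CC[C@@]5(C)C[C@]43CC5=O)nn2)cc1` gives > 20000 nM, likewise only a limit.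
Compound 3 `C=C1C[C@]23C[C@@]1(O)CC[C@H]2c1ccc(OS(=O)(=O)c2ccc(C)cc2)c(C)c1[C@@H]3Cn1cc(-c2ccccc2)nn1` gives > 20000 nM, again a limit.

So compound 2 stands at the limit in this assay, and every other value shown does the same, as the limit of > 20000 nM in this assay, at which 3 of the 3 values shown sit, records. Among the measured compounds shown here, no pair of measured compounds differs in a single place, so no measured step can be sized here. Compound 4 `Cc1c(O)ccc2c1[C@H](Cn1cc(-c3ccc(Cl)cc3)nn1)[C@@]13CC(=O)[C@@](C)(CC[C@@H]21)C3` differs from compound 2 by chloro in place of methoxy on an aromatic carbon. Without a measured step to lean on, the expected change from compound 2 to compound 4 is a step that the limit leaves unreadable from compound 2 to compound 4, none beyond the scatter. Compound 4 is therefore expected to give 30000 nM, within 12000 nM to 80000 nM, most probably reported only as a limit.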

Compound 4, half-maximal inhibitory concentration: > 20000 nM
Compound 4 ended at the assay's limit; the forecaster's own chance of this, stated with the estimate: 80%; the middle value does not contradict the limit.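

Compound 2 gives > 20000 nM, a limit of the assay. Compound 4 gives > 20000 nM, also a limit, so the step cannot be read. The compounds shown leave open which structure, if any, would give a measurable value in this assay.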